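The source may report more compounds than this note shows. Statements on the series, on what has been measured and on what is new or still open speak of the compounds shown alone.

Among the measured compounds shown here, compound 2 `CCCCCCCCCCCCn1nnc(C(C(=O)Nc2c(C(C)C)cccc2C(C)C)c2ccccn2)n1` gives 26 nM in an assay on liver for inhibition of sterol O-acyltransferase 1 (Rattus norvegicus), using microsomes (on this read-out higher numbers stand for weaker inhibition and lower numbers for stronger inhibition), the only number measured in this set. Compound 1 `CCCCCCCCCCCCn1nnc(C(C(=O)Nc2c(C(C)C)cccc2C(C)C)c2nnn[nH]2)n1` reaches only the limit of this assay, > 5000 nM, which is the limit of > 5000 nM in this assay, at which 1 of the 2 values shown sits. Compound 3 `CCCCCCCCCCCCn1nnc(CC(=O)Nc2c(C(C)C)cccc2C(C)C)n1` differs from compound 2 by hydrogen in place of pyridin-2-yl on a saturated chain carbon bound to an aromatic carbon and a carbonyl carbon. For the measured compounds named here, the one measured change at this carbon, an at least 190-fold lower number from compound 1 to compound 2 (2.28 log units; beyond the scatter), shows that what sits there can shift the number far, yet stripping the group to hydrogen was never tested, so the expected step of a 12-fold higher number from compound 2 to compound 3 (1.06 log units; beyond the scatter) is a weakening of uncertain size. Compound 3 is therefore estimated at 300 nM, within 30 nM to 3000 nM.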

Compound 3, half-maximal inhibitory concentration: 5 nM
The estimate for compound 3 lay 60-fold (1.78 log units) above the measured number; measured number below the stated range.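

In this assay, plain hydrogen on this carbon outperforms pyridin-2-yl, with a 5.2-fold lower number from compound 2 to compound 3 (0.72 log units; beyond the scatter), so strong inhibition here needs no ring at this place. Compared with 1H-tetrazol-5-yl, the same hydrogen gives an at least 1000-fold lower number from compound 1 to compound 3 (3.00 log units; beyond the scatter), so both rings tested leave the number higher than hydrogen does, the tetrazole far more so. The value of compound 1 is a limit, not a number: the limit of > 5000 nM in this assay, at which 1 of the 3 values shown sits.

As far as these compounds go, whether a small group on this carbon, such as methyl, fluorine or hydroxyl, would keep the number as low as hydrogen does remains open.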